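This account rests on a few compounds, and the source may have more. Where it says the series, first, only, none or still open, it means among the compounds named here.

Measured so far:
compound 1 `CCCC(=O)OCSc1ccc(OC(F)(F)F)cc1C(=O)NC(C)(C)C(N)=O` — < 56.1 uM (a limit)
compound 2 `CCCC(=O)OCSc1ccccc1C(=O)NCCCCCCNC(C)=O` — 8 uM
compound 3 `CCCC(=O)OCSc1ccccc1C(=O)N(C)CC(=O)NC` — 62.5 uM

In an ADME assay on CEM-SS cells (Homo sapiens) for cytotoxicity, read by XTT assay, with a stated time of 6 days (a higher number here means that more compound is tolerated, a lower number that less compound is tolerated), compound 2 gives 8 uM, the lowest of the two numbers shown. Compound 3 gives 62.5 uM, a higher number, and the gap between compound 3 and compound 2 lies beyond the usual scatter. For compound 1 only a limit is known, < 56.1 uM; this is the limit of < 56.1 uM in this assay, at which 1 of the 3 values shown sits, and not a number. Going by the values given here, no step between two measured compounds that differ in a single place is available, so no measured step can be named as a guide.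

Compound 4 `CCCC(=O)OCSc1ccccc1C(=O)NCC(=O)NC(C)(C)C` has not yet been measured in this assay. It differs from compound 2 by (tert-butyl)carbamoyl in place of 5-acetamidopentyl on a saturated chain carbon bound to an amide-type nitrogen.

The expectation rests on the two numbers at hand: compound 2 at 8 uM and compound 3 at 62.5 uM. With the long chain of compound 2 gone, compound 4 is expected to sit closer to compound 3 than to compound 2, and the step from compound 2 to compound 4 is expected to be an increase, of about a 3.8-fold higher number from compound 2 to compound 4 (0.57 log units; beyond the scatter), beyond the scatter. The estimate for compound 4 in this assay is 30 uM, with a range from 10 uM to 90 uM.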

Compound 4, half-maximal toxic concentration: 46.8 uM
Beside the measured number, compound 4's estimate is 1.6-fold (0.19 log units) below it; measured number inside the range.
By their numbers in this assay, from the lowest: compound 2; then compounds 4 and 3 (each within the scatter of the next).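

In this assay, the series now has its first single-place step, a 5.9-fold higher number from compound 2 to compound 4 (0.77 log units; beyond the scatter), at the saturated chain carbon bound to an amide-type nitrogen. The low number of compound 2 could not be tied to any part of its structure before; it now goes with the 5-acetamidopentyl group when set against (tert-butyl)carbamoyl, so the substituent at this place matters for how much compound the cells tolerate. The change also leaves the counts of hydrogen-bond donors, hydrogen-bond acceptors and double bonds outside aromatic rings the same, with no ring and no net charge on either side, so those counts do not track the step in this pair.

A single exchange cannot separate the length of the chain from its terminal acetamide, and a plain hexyl chain, or a 5-aminopentyl group or a chain ending in a carboxylic acid at the same place, would be needed to pull these apart. Nothing measured here bears on why the number changes with this exchange.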